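A few compounds are considered here, and "the series" means these few. Any claim that something is new, unique, unknown or untested is made for them only; others in the source may bear on it.

Measured so far in an assay on isolated protein for inhibition of DNA topoisomerase 1 (Homo sapiens), with a stated time of 30 min, tested at 100 uM; a lower number here means less inhibition, a higher number more inhibition at the concentration tested (going by the name of the read-out):

compound 1 `Cc1ccsc1-c1cc(-c2ccc(Cl)o2)cc(-c2cccc(Cl)c2)n1`: 5.9%
compound 2 `Clc1ccc(-c2cc(-c3ccco3)nc(-c3ccc(Cl)s3)c2)o1`: 23.1%
compound 3 `Cc1ccc(-c2cc(-c3ccc(Cl)o3)cc(-c3ccc(Cl)s3)n2)cc1`: 14.2%

All three numbers lie within the usual scatter of one another. Compound 3 is nearest to compound 1 and furthest from compound 2, and neither gap reaches beyond the scatter, so no order among the three can be read from the data.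

The next compound is compound 4 `Clc1cccc(-c2cc(-c3ccc(Cl)o3)cc(-c3ccc(Cl)s3)n2)c1`. It differs from compound 3 in one place: 3-chlorophenyl in place of 4-methylphenyl on an aromatic carbon.

Going by the values given here, one measured step touches the same position: a number 8.9 percentage points lower from compound 2 to compound 3 (within the scatter). That exchange, a different group entering at the same carbon, left the read-out within the scatter. Among the compounds with values here, no step with 3-chlorophenyl entering is measured; compound 1, which carries a 3-chlorophenyl at that position but another group elsewhere, gives 5.9%, which is within the scatter of compound 3 as well.

With only a within-scatter step at this position and a 3-chlorophenyl-bearing compound at a similar level, no step beyond the scatter is expected for compound 4: a number 2.2 percentage points lower from compound 3 to compound 4 (within the scatter). Compound 4 is therefore estimated at 12%, expected to fall between 0% and 28%.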

Compound 4, a percentage reported as inhibition, at one concentration (the size of the read-out at that concentration, not a potency): 13.3%
Beside the measured number, compound 4's estimate is 1.3 percentage points below it, and the stated range covers the measured number.
By their numbers in this assay, from the lowest: compounds 1, 4, 3 and 2 (each within the scatter of the next, the first and the last beyond it).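

In this assay, going by these compounds alone, the exchange of 4-methylphenyl for 3-chlorophenyl on the aromatic carbon next to the ring nitrogen gives a number 0.9 percentage points lower from compound 3 to compound 4 (within the scatter) and is the first direct reading of 3-chlorophenyl entering at this place. Against furan-2-yl at the same carbon, 3-chlorophenyl gives a number 9.8 percentage points lower from compound 2 to compound 4 (within the scatter) and so furan-2-yl, 4-methylphenyl and 3-chlorophenyl now stand within the scatter of one another at this position, with no order among them. With 3-chlorophenyl held in place, 5-chlorothiophen-2-yl in place of 3-methylthiophen-2-yl at the other position gives a number 7.4 percentage points higher from compound 1 to compound 4 (within the scatter) and no supporting finding is available to explain any of these steps.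

As far as these compounds go, every group read at this carbon so far is a single aromatic ring, so it remains open whether a morpholine, a carboxylic acid or a longer alkyl chain there would give a step beyond the scatter. Also open is what the chlorine of the 3-chlorophenyl group contributes, since a plain phenyl group is not among the compounds shown for comparison at this position.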